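From fluoro to chloro on an aromatic carbon

The source may hold more compounds than are shown below. What is called first, only, known or untested is meant among the compounds shown, and "the series" means these compounds.

Measured so far in a physicochemical assay for solubility; on this read-out lower numbers stand for lower solubility and higher numbers for higher solubility:
compound 1 `COc1cc(OC)c(/C=C/S(=O)(=O)Nc2ccc(OC)c(NCC(=O)O)c2)c(OC)c1` gives 10000 ug/mL
compound 2 `COc1cc(OC)c(/C=C/S(=O)(=O)Nc2ccc(OC)c(NC(C(=O)O)c3ccc(F)cc3)c2)c(OC)c1` gives 10000 ug/mL

On these numbers, compound 2 stands level with compound 1. The next structure, compound 3 `COc1cc(OC)c(/C=C/S(=O)(=O)Nc2ccc(OC)c(NC(C(=O)O)c3ccc(Cl)cc3)c2)c(OC)c1`, differs from compound 2 as follows: chloro in place of fluoro on an aromatic carbon. Put simply, compound 3 carries chloro where compound 2 carries fluoro, para to a large group. Within the data shown here, one measured step bears on this, the entry of 4-fluorophenyl in place of hydrogen, and it showed no change at the digits printed from compound 1 to compound 2 (within the scatter) in the measurements. That change was the bigger of the two in structure, yet it left the reading where it was. Among the measured compounds shown here, no measured pair shows the exchange of fluoro for chloro itself, so the expectation rests on that single step. No shift beyond the scatter is expected in this assay, and the expected step is no change at the digits printed from compound 2 to compound 3 (within the scatter) in size. The estimate for compound 3 is 10000 ug/mL (expected range 5000 ug/mL to 15000 ug/mL).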

Compound 3, solubility: 10000 ug/mL
Compound 3: middle estimate and measured number agree at the digits printed, within the range that was stated.
By their numbers in this assay, from the lowest: compounds 1, 2 and 3 (each within the scatter of the next).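

In this assay, the exchange of one halogen for the other now has a measured step of its own, no change at the digits printed from compound 2 to compound 3 (within the scatter), so this aromatic carbon has taken both fluoro and chloro with the reading unmoved. Measured against hydrogen on the saturated chain carbon, the 4-chlorophenyl group gives no change at the digits printed from compound 1 to compound 3 (within the scatter), which matches what the 4-fluorophenyl group showed at that carbon. Nothing among the data shown accounts for this flat reading.

The compounds shown leave open how this assay would read with an amine or a nitrile on this aromatic carbon in place of the halogen. They also leave open whether a longer chain in place of the 4-chlorophenyl group on the saturated chain carbon would read the same.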